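A few compounds are considered here, and "the series" means these few. Any claim that something is new, unique, unknown or untested is made for them only; others in the source may bear on it.

Compound 1, with the structure `Cc1noc(C)c1-c1cnc(N)c(Oc2ccc(C(=O)Nc3ccc(Cl)cc3)cc2)n1`, is the starting point. In a functional assay on LoVo cells (Homo sapiens) for inhibition, read by MTT assay, with a stated time of 72 h (a higher number here means a weaker inhibitor, a lower number a stronger inhibitor), compound 1 gives 1920 nM. Compound 2, `Cn1cc(-c2cnc(N)c(Oc3ccc(C(=O)Nc4ccc(Cl)cc4)cc3)n2)cn1`, differs from compound 1 in one place: 1-methyl-1H-pyrazol-4-yl in place of 3,5-dimethyl-1,2-oxazol-4-yl on an aromatic carbon. This change produced a 1.6-fold higher number from compound 1 to compound 2 (0.21 log units; within the scatter), and in this assay compound 2 gives 3080 nM, so the two values cannot be told apart by this measurement.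

Compound 3, `Cc1noc(C)c1-c1cnc(N)c(NCc2ccc(C(=O)Nc3ccc(Cl)cc3)cc2)n1`, carries the same dimethyl-oxazole group as compound 1 but on a different core; how the two cores differ is not broken down here. For compound 3 this assay reports only a limit, > 100000 nM, which means no number was reached. That limit is described by the limit of > 100000 nM in this assay, at which 1 of the 3 values shown sits.

Compound 4, `Cn1cc(-c2cnc(N)c(NCc3ccc(C(=O)Nc4ccc(Cl)cc4)cc3)n2)cn1`, has not yet been measured. It stands to compound 3 as compound 2 stands to compound 1, the same change at the same place: 1-methyl-1H-pyrazol-4-yl in place of 3,5-dimethyl-1,2-oxazol-4-yl on an aromatic carbon. The earlier step, a 1.6-fold higher number from compound 1 to compound 2 (0.21 log units; within the scatter), lay within the usual scatter, so the same kind of swap is expected to shift compound 4 little from compound 3. Since compound 3 gives only a limit, the most that can be expected is a step of about a number no higher from compound 3 to compound 4 (the limit leaves the size open), with compound 4 most likely also landing outside the measurable range. The estimate for compound 4 in this assay is 100000 nM, within a range from 30000 nM to 300000 nM.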

Compound 4, half-maximal inhibitory concentration: 43600 nM
Estimate against measurement, compound 4: 2.3-fold (0.36 log units) above; low and high end bracket the measured number.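

On the core of compound 3, putting 1-methyl-1H-pyrazol-4-yl in place of 3,5-dimethyl-1,2-oxazol-4-yl produced an at least 2.2-fold lower number from compound 3 to compound 4 (0.36 log units; beyond the scatter) in this assay, whereas the same swap on the core of compound 1 made no difference that this measurement could detect. The value of compound 3, > 100000 nM, is a limit and not a number. These two pairs show that, in this series, the effect of the swap does not carry over unchanged from one core to the other, but they do not show why, how large the step on the second core really is, or how the swap would behave on a third core: the same change on two cores in this assay, a 1.6-fold higher number (0.21 log units; within the scatter) from compound 1 to compound 2 and an at least 2.2-fold lower number (0.36 log units; beyond the scatter) from compound 3 to compound 4, at least 3.6-fold (0.56 log units) apart, beyond the scatter of two such steps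

The compounds shown leave open what other groups would do on this same aromatic carbon, such as an amine, a carboxylic acid or a longer chain, and whether any of them would behave alike on both cores. Among these compounds, they also leave open whether the gap between the two cores would persist with such groups, since only two groups have been compared here at this place on each core.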